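Predicting a Urea-Substituent Swap on a Thienopyrimidine Series

A few compounds are considered here, and "the series" means these few. Any claim that something is new, unique, unknown or untested is made for them only; others in the source may bear on it.

Measured compounds:
compound 1, `CN(C)CCNc1nc(-c2ccc(NC(=O)Nc3ccccc3F)cc2)nc2ccsc12`, 410 nM
compound 2, `CN(C)CCNc1nc(-c2ccc(NC(=O)Nc3ccc(Cl)cc3)cc2)nc2ccsc12`, 130 nM
compound 3, `CCN(CC)CCCNc1nc(-c2ccc(NC(=O)Nc3ccccc3F)cc2)nc2ccsc12`, 370 nM

All three were tested in a functional assay on NCI-H460 cells (Homo sapiens) for cytotoxicity, read by MTT assay, with a stated time of 72 h; a higher number here means a weaker inhibitor, a lower number a stronger inhibitor. Compound 1 gives 410 nM, compound 2 gives 130 nM, and compound 3 gives 370 nM. Compound 1 and compound 3 differ only in the chain on the shared core, ((diethylamino)methyl in place of dimethylamino on a saturated chain carbon, two bonds along the chain from a nitrogen on an aromatic ring), and their values sit within the scatter of each other, so a 1.1-fold lower number from compound 1 to compound 3 (0.04 log units; within the scatter) counts as no real change. The change from compound 1 to compound 2, (4-chlorophenyl in place of 2-fluorophenyl on an amide-type nitrogen), gave a 3.2-fold lower number from compound 1 to compound 2 (0.50 log units; beyond the scatter).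

Compound 4, `CCN(CC)CCCNc1nc(-c2ccc(NC(=O)Nc3ccc(Cl)cc3)cc2)nc2ccsc12`, has not been measured. It relates to compound 3 exactly as compound 2 relates to compound 1: 4-chlorophenyl in place of 2-fluorophenyl on an amide-type nitrogen, and the place is described in the same words for both pairs, so this is the same change made on a different chain. The chain itself made no difference between compound 1 and compound 3. The step already seen, a 3.2-fold lower number from compound 1 to compound 2 (0.50 log units; beyond the scatter), is therefore expected to repeat on the longer chain. For compound 4 this gives an estimated 3.1-fold lower number from compound 3 to compound 4 (0.49 log units; beyond the scatter). Compound 4 is therefore expected to give about 120 nM, within a range from 50 nM to 300 nM.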

Compound 4, half-maximal inhibitory concentration: 81 nM
The estimate for compound 4 lay 1.5-fold (0.17 log units) above the measured number, and the stated range covers the measured number.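

Putting 4-chlorophenyl in place of 2-fluorophenyl on the amide-type nitrogen also lowered the number in this assay on the longer chain, with a 4.6-fold lower number from compound 3 to compound 4 (0.66 log units; beyond the scatter), and the two steps for this change agree within the scatter: the same change on two cores in this assay, a 3.2-fold lower number (0.50 log units; beyond the scatter) from compound 1 to compound 2 and a 4.6-fold lower number (0.66 log units; beyond the scatter) from compound 3 to compound 4, 1.4-fold (0.16 log units) apart, within the scatter of two such steps

The swap of chain stayed within the scatter on the 4-chlorophenyl compounds too, with a 1.6-fold lower number from compound 2 to compound 4 (0.21 log units; within the scatter), and it agrees with the same swap on the 2-fluorophenyl compounds: the same change on two cores in this assay, a 1.1-fold lower number (0.04 log units; within the scatter) from compound 1 to compound 3 and a 1.6-fold lower number (0.21 log units; within the scatter) from compound 2 to compound 4, 1.4-fold (0.16 log units) apart, within the scatter of two such steps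

So in these four compounds each change gave much the same step whichever form the other part took, but this rests on just two chains and two aryl groups in this assay, and it does not show that the step would carry over to other chains or explain why the step occurs.

The swap alters both the halogen and its place on the phenyl ring at once, so the compounds shown cannot say which of the two matters. They also leave open how an unsubstituted phenyl group, or a chain ending in a morpholine, would behave.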